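The source may hold more compounds than are shown below. What is called first, only, known or untested is meant among the compounds shown, and "the series" means these compounds.

Measured in a functional assay on MKN-45 cells (Homo sapiens) for inhibition, read by colorimetric assay and sulforhodamine B assay, with a stated time of 48 h (a higher number here means a weaker inhibitor of growth, a lower number a stronger inhibitor of growth), so far:
- compound 1 `CCCCCCCCCCCC[C@@H](O)[C@H]1CC[C@H]([C@H](O)CCCCCCCCCCNC(=O)c2cccs2)O1` gives 3310 nM
- compound 2 `CCCCCCCCCCCC[C@@H](O)[C@H]1CC[C@H]([C@H](O)CCCCCCCCCCNC(=O)c2ccoc2)O1` gives 100000 nM
- compound 3 `CCCCCCCCCCCC[C@@H](O)[C@H]1CC[C@H]([C@H](O)CCCCCCCCCCNC(=O)c2cncs2)O1` gives 100000 nM

Compound 3 stands level with compound 2, and these two share the highest number of the three. Compound 4 `CCCCCCCCCCCC[C@@H](O)[C@H]1CC[C@H]([C@H](O)CCCCCCCCCCNC(=O)c2ccsc2)O1` differs from compound 3 in one place, with thiophen-3-yl in place of 1,3-thiazol-5-yl on a carbonyl carbon.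

For the measured compounds named here, three measured steps bear on this. Two are large: a 30-fold higher number from compound 1 to compound 2 (1.48 log units; beyond the scatter) and a 30-fold higher number from compound 1 to compound 3 (1.48 log units; beyond the scatter) both start from the thiophen-2-yl of compound 1. The third, no change at the digits printed from compound 2 to compound 3 (within the scatter) shows that the furan-3-yl and 1,3-thiazol-5-yl compounds cannot be told apart here.

Going by the values given here, compound 4 is also a thiophene, but no measured compound carries thiophen-3-yl, so a full return to the level of compound 1 cannot be assumed. Expected in this assay is a 10-fold lower number from compound 3 to compound 4 (1.00 log units; beyond the scatter) as a move to a lower number, covering only part of that distance. Compound 4 is estimated at 10000 nM with an expected range of 2000 nM to 100000 nM in this estimate.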

Compound 4, concentration for 50% growth inhibition: 3720 nM
Compound 4: the middle estimate sits 2.7-fold (0.43 log units) above what was measured; the range from low to high includes it.
By their numbers in this assay, from the lowest: compounds 1 and 4 (each within the scatter of the next); then compounds 2 and 3 (each within the scatter of the next).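

In this assay, moving from thiophen-2-yl to thiophen-3-yl on this carbonyl carbon makes no difference that can be read (a 1.1-fold higher number from compound 1 to compound 4 (0.05 log units; within the scatter)). Both rings in the other compounds have the same count of heavy atoms as thiophen-3-yl, yet the number still shifts sharply: replacing 1,3-thiazol-5-yl gives a large step (a 27-fold lower number from compound 3 to compound 4 (1.43 log units; beyond the scatter)), and so does replacing furan-3-yl (a 27-fold lower number from compound 2 to compound 4 (1.43 log units; beyond the scatter)). The four compounds thus fall into two groups, the two thiophenes and the other two rings, and no measurement at hand explains that split.

Still open, as far as these compounds go, is how a phenyl ring or a pyridin-3-yl ring would behave on this carbonyl carbon. Also open, from the compounds shown here alone, is whether a methyl group on the thiophene ring would keep the number where the two thiophenes put it.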